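A few compounds are considered here, and "the series" means these few. Any claim that something is new, unique, unknown or untested is made for them only; others in the source may bear on it.

In a functional assay on HeLa cells (Homo sapiens) for inhibition, read by MTT assay, with a stated time of 72 h (a lower number here means a stronger inhibitor, a higher number a weaker inhibitor), compound 1 `COc1cccc(/C=C/C(=O)Nc2cc(OC)c(OC)c(OC)c2)c1` gives 16500 nM and compound 2 `C=C(Br)C(=O)Nc1cccc(/C=C/C(=O)Nc2ccccc2)c1` gives 7300 nM while compound 3 `C=C(Br)C(=O)Nc1cccc(/C=C/C(=O)Nc2cccc3ccccc23)c1` gives 1400 nM on the same scale. Compound 2 thus stands second highest of the three numbers, with compound 1 higher and compound 3 lower. Both gaps lie beyond the usual scatter, and the gap to compound 3 is the larger.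

Compound 4 `C=C(Br)C(=O)Nc1cccc(/C=C/C(=O)Nc2ccc(F)cc2)c1` has not yet been measured. Its change from compound 2 is fluoro in place of hydrogen on an aromatic carbon in one place, fluoro in place of hydrogen on an aromatic carbon, so that phenyl becomes 4-fluorophenyl. Within the data shown here, no measured pair differs in one place only, and the size of this step has no direct precedent. With compound 2 at 7300 nM as the reference point, the expectation in this assay is a small shift towards a lower number, none beyond the scatter. The expected size of the step of a 1.2-fold lower number from compound 2 to compound 4 (0.09 log units; within the scatter) stays within the scatter. Compound 4 is estimated at 6000 nM with an expected range from 2500 nM to 13000 nM in this read-out.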

Compound 4, half-maximal inhibitory concentration: 16800 nM
For compound 4 the middle estimate is 2.8-fold (0.45 log units) below the measured one, outside the stated range (above it).
By their numbers in this assay, from the lowest: compound 3; then compound 2; then compounds 1 and 4 (each within the scatter of the next).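

In this assay, phenyl to 4-fluorophenyl gives the series its first step in a single place, a 2.3-fold higher number from compound 2 to compound 4 (0.36 log units; beyond the scatter), which is modest but moves towards a weaker inhibitor. Among these compounds, this position, on the six-membered aromatic ring para to a large group, therefore responds to the exchange of a hydrogen atom for a single fluorine atom, a change that the earlier compounds could not test. No supporting measurement bears on why the number rises with fluoro here.

With a single substituent at this position, the step gives a direction for fluoro alone. Going by these compounds, whether chloro, methoxy, an amine or a carboxylic acid in the same place would also raise the number remains open, as does the effect of fluoro elsewhere on this ring.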